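One methyl on an amide at the toxicity limit

The compounds below may be only part of what the source reports. "The series", "measured", "known", "first", "only" and "open" are said of these compounds alone.

Values in an ADME assay on HeLa cells (Homo sapiens) for cytotoxicity, read by crystal violet staining, with a stated time of 72 h (on this read-out higher numbers stand for lower toxicity in this test and lower numbers for higher toxicity in this test), follow, each of them a limit of the assay and not a number.

Compound 1 `Cc1cc(-c2noc(C(F)(F)F)n2)cc(C)c1OCCCc1cc(-c2ccccc2)no1` gives > 100000 nM
Compound 2 `Cc1cc(-c2noc(C(F)(F)F)n2)cc(C)c1OCCCc1cc(-c2ccc(OC(F)(F)F)cc2)no1` gives > 100000 nM
Compound 3 `Cc1cc(-c2noc(C(F)(F)F)n2)cc(C)c1OCCCc1cc(C(N)=O)no1` gives > 100000 nM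

For the measured compounds named here, compound 3 stands with compound 1 and compound 2 on the only reading available (the limit of > 100000 nM in this assay, at which 3 of the 3 values shown sit). From the compounds shown here alone, its exact place is unknown, and no ranking among the three can be drawn.

Compound 4 `CNC(=O)c1cc(CCCOc2c(C)cc(-c3noc(C(F)(F)F)n3)cc2C)on1` differs from compound 3 by one change (methyl in place of hydrogen on an amide-type nitrogen), methyl in place of hydrogen on an amide-type nitrogen, which turns carbamoyl to methylcarbamoyl.

Three measured steps lie nearby (a step that the two limits leave unreadable from compound 1 to compound 2; a step that the two limits leave unreadable from compound 1 to compound 3; a step that the two limits leave unreadable from compound 2 to compound 3) and none gives a size to carry over. The second and third exchange the group that compound 4 alters, yet all three compounds end at the same limit. None of them tests a methyl on this nitrogen.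

No step beyond the scatter is therefore expected in this assay in either direction. The expected step is a number no higher from compound 3 to compound 4 (the limit leaves the size open) for this change. For compound 4 the estimate is 100000 nM with a range from 40000 nM to 250000 nM and a report of a limit alone would be no surprise.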

Compound 4, half-maximal cytotoxic concentration: > 100000 nM
Compound 4 was reported as a limit; the forecaster's own chance of this, stated with the estimate: 85%; the middle value sits exactly at the limit.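

Compound 4 gives > 100000 nM in this assay, a limit and not a number. No step from compound 1, compound 2 or compound 3 to compound 4 can be read, and the shared reading is the reason: the limit of > 100000 nM in this assay, at which 4 of the 4 values shown sit. The compounds shown leave open where each of the four truly lies in this assay, and so whether methyl in place of hydrogen on the amide-type nitrogen makes any difference there.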